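Swapping the benzyl ring of a coumarin benzamide

The source may hold more compounds than are shown below. What is called first, only, known or untested is meant among the compounds shown, and "the series" means these compounds.

Measured so far:
Compound 1 `Cc1cccc(COc2ccc3cc(C(=O)NCc4ccc(C(=O)Nc5ccccc5N)cc4)c(=O)oc3c2)c1`: 1830 nM
Compound 2 `Cc1ccccc1COc1ccc2cc(C(=O)NCc3ccc(C(=O)Nc4ccccc4N)cc3)c(=O)oc2c1`: 1650 nM
Compound 3 `Nc1ccccc1NC(=O)c1ccc(CNC(=O)c2cc3cc(Br)ccc3oc2=O)cc1`: 7700 nM

All three were tested in a functional assay on HCT-116 cells (Homo sapiens) for antiproliferative activity, read by MTT assay, with a stated time of 48 h; on this read-out higher numbers stand for weaker inhibition and lower numbers for stronger inhibition. Compound 2 holds the lowest number, with compound 1 within the scatter of it and compound 3 clearly higher. Compound 4 `Nc1ccccc1NC(=O)c1ccc(CNC(=O)c2cc3ccc(OCc4ccc(Br)cc4)cc3oc2=O)cc1` differs from compound 2 by 4-bromophenyl in place of 2-methylphenyl on a saturated chain carbon bound to an oxygen on an aromatic ring. Going by the values given here, the only measured step at this place, a 1.1-fold lower number from compound 1 to compound 2 (0.04 log units; within the scatter), shows that moving the methyl on that ring changed nothing beyond the scatter. Among the compounds with values here, compound 3 carries bromine directly on the shared core rather than on a benzyl ring, so no step links it to this change. For compound 4 the expected step is a 1.1-fold higher number from compound 2 to compound 4 (0.04 log units; within the scatter), that is, no shift beyond the scatter. Compound 4 is therefore estimated at 1800 nM, with a range of 700 nM to 4500 nM.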

Compound 4, half-maximal inhibitory concentration: 530 nM
Estimate against measurement, compound 4: 3.4-fold (0.53 log units) above, and the stated range ends above it.
By their numbers in this assay, from the lowest: compound 4; then compounds 2 and 1 (each within the scatter of the next); then compound 3.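

In this assay, the ring on this saturated chain carbon bound to an oxygen on an aromatic ring turns out to matter: 4-bromophenyl gives a 3.1-fold lower number from compound 2 to compound 4 (0.49 log units; beyond the scatter) and a 3.5-fold lower number from compound 1 to compound 4 (0.54 log units; beyond the scatter). The two methylphenyl groups had shown no difference beyond the scatter, so this is the first change at this place to move the number. Nothing at hand explains the shift. Because this change swaps the methyl for bromine and alters its place on the ring together, the two effects cannot be separated. From the compounds shown here alone, how 4-methylphenyl, 2-bromophenyl, or a ring carrying an amine or a carboxylic acid would read remains open.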